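The source may hold more compounds than are shown below. What is called first, only, known or untested is meant among the compounds shown, and "the series" means these compounds.

Measured so far:
compound 1 `Fc1ccc2nc(-c3cn[nH]c3)n(C3CC3)c2c1` gives 1670 nM;
compound 2 `Cc1ncncc1-c1nc2cc(F)c(F)cc2n1C1CC1` gives 4160 nM.

In an ADME assay on cells for inhibition of cytochrome P450 11B1, mitochondrial (Homo sapiens), read by HPLC, with a stated time of 60 min (a higher number here means a weaker inhibitor, a lower number a stronger inhibitor), compound 2 stands at the higher of these two numbers, the weaker inhibitor of the pair. Compound 3 `Fc1cc2nc(-c3cncnc3NCCC(F)(F)F)n(C3CC3)c2cc1F` keeps the core of compound 2 and changes one place: (3,3,3-trifluoropropyl)amino in place of methyl on an aromatic carbon. Going by the values given here, no pair of measured compounds shows the effect of such a change, so the direction of the step cannot be read from the numbers. Compound 3 is expected to land near compound 2, with the step of a 2.1-fold lower number from compound 2 to compound 3 (0.32 log units; beyond the scatter) taken as an estimate of uncertain sign. For compound 3 the estimated value is 2000 nM, within 500 nM to 8000 nM.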

Compound 3, half-maximal inhibitory concentration: 378 nM
For compound 3 the middle estimate is 5.3-fold (0.72 log units) above the measured one, outside the stated range (below it).
By their numbers in this assay, from the lowest: compound 3; then compound 1; then compound 2.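

Putting (3,3,3-trifluoropropyl)amino in place of methyl on this aromatic carbon gives an 11-fold lower number from compound 2 to compound 3 (1.04 log units; beyond the scatter) in this assay. This position, on the six-membered aromatic ring with 2 nitrogen, therefore accepts a much larger group than methyl, and the change brings much stronger inhibition. Nothing available explains this gain.

The compounds shown leave open whether the gain follows the linking nitrogen or the fluorinated chain. A plain propylamino chain or an unsubstituted amine at this position would separate the two.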